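The compounds below may be only part of what the source reports. "The series", "measured", "known", "first", "only" and "open" are said of these compounds alone.

Measured so far in an ADME assay for permeability, using PAMPA, with a stated time of 30 min, at pH 7.4; on this read-out lower numbers stand for lower permeability and higher numbers for higher permeability:

compound 1, `COc1cccc(CNCCCNc2ccnc3cc(Oc4ccc(Cl)cc4)ccc23)c1O`: 317 10^-6 cm/s
compound 2, `CCC(CC)c1ccc2c(NCCCNCc3ccco3)ccnc2c1`: 23 10^-6 cm/s
compound 3, `c1ccc(Cc2ccc3c(NCCCNCc4ccco4)ccnc3c2)cc1`: 23 10^-6 cm/s

Compound 3 stands level with compound 2 at the digits shown, and these two together are the lowest of the three numbers. Its nearest neighbour is compound 2, the step of no change at the digits printed from compound 2 to compound 3 (within the scatter) lying within the scatter. Among the measured compounds shown here, the furthest is compound 1, whose number sits beyond the scatter above that of compound 3; compound 1 carries a 4-chlorophenoxy group on its core but also a different amine tail, so no single-point step connects it to compound 3, and only the two values themselves can be compared.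

Compound 4, `Clc1ccc(Oc2ccc3c(NCCCNCc4ccco4)ccnc3c2)cc1`, has not yet been measured in this assay. 4-chlorophenoxy in place of benzyl on an aromatic carbon

For the measured compounds named here, the one measured step at this carbon, no change at the digits printed from compound 2 to compound 3 (within the scatter), was flat, but it exchanged two carbon-only groups and says nothing about 4-chlorophenoxy. The value of compound 1 shows that a member of the series bearing 4-chlorophenoxy can reach a far higher number, yet its tail differs as well, so that number cannot be carried over directly. A rise is therefore expected for compound 4, a 2.6-fold higher number from compound 3 to compound 4 (0.42 log units; beyond the scatter), with wide uncertainty. The estimate for compound 4 in this assay is 60 10^-6 cm/s, expected to fall between 18 10^-6 cm/s and 220 10^-6 cm/s.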

Compound 4, apparent permeability: 317 10^-6 cm/s
For compound 4 the middle estimate is 5.3-fold (0.72 log units) below the measured one; the measured number lies above the stated range.
By their numbers in this assay, from the lowest: compounds 2 and 3 (each within the scatter of the next); then compounds 1 and 4 (each within the scatter of the next).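

In this assay this aromatic carbon is not indifferent to what it carries: the flat step no change at the digits printed from compound 2 to compound 3 (within the scatter) exchanged two carbon-only groups, whereas 4-chlorophenoxy gives a 14-fold higher number from compound 3 to compound 4 (1.14 log units; beyond the scatter) and, against pentan-3-yl, a 14-fold higher number from compound 2 to compound 4 (1.14 log units; beyond the scatter). With 4-chlorophenoxy in place, the exchange of 2-hydroxy-3-methoxyphenyl for furan-2-yl on the amine tail gives no change at the digits printed from compound 1 to compound 4 (within the scatter), so in this pair the tail change leaves the number unmoved, and the high value of compound 1 is matched with the simpler furan-2-yl tail. Nothing available accounts for the large rise at this carbon.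

Open, on these data alone, is which part of the entering group goes with the rise, since the ether oxygen and the chlorine arrive together: a plain phenoxy group and a 4-chlorobenzyl group would separate them. Also open, as far as these compounds go, is how this carbon responds to an amine or a carboxylic acid, and whether benzyl or pentan-3-yl on the shared core would give the same low number with the 2-hydroxy-3-methoxyphenyl tail.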